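Methoxy on the pendant phenyl: a repeated change

The source may hold more compounds than are shown below. What is called first, only, known or untested is meant among the compounds shown, and "the series" means these compounds.

Three members of the series have been measured in a functional assay on A549 cells (Homo sapiens) for cytotoxicity, read by MTT assay, with a stated time of 72 h; on this read-out higher numbers stand for weaker inhibition and lower numbers for stronger inhibition. Compound 1 `O=S(=O)(c1ccccc1)c1nc2ccccc2nc1Nc1ccc(Cl)cc1` gives 30700 nM. Compound 2 `COc1ccc(S(=O)(=O)c2nc3ccccc3nc2Nc2ccc(Cl)cc2)cc1` carries the change methoxy in place of hydrogen on an aromatic carbon relative to compound 1, and in this assay compound 2 gives 87300 nM; the step is a 2.8-fold higher number from compound 1 to compound 2 (0.45 log units; beyond the scatter). Compound 3 `O=S(=O)(c1ccc(Br)cc1)c1nc2ccccc2nc1Nc1ccccc1` gives 10800 nM, the lowest of the three numbers. The difference between the core of compound 3 and the core of compound 1 is not broken down here; their values simply show compound 3 lower than compound 1.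

Compound 4 `COc1ccc(Nc2nc3ccccc3nc2S(=O)(=O)c2ccc(Br)cc2)cc1` is not yet measured. It differs from compound 3 by methoxy in place of hydrogen on an aromatic carbon. This is the same change that separates compound 2 from compound 1: in both cases methoxy enters for hydrogen on an aromatic carbon, and the place is described in the same words for both pairs. Among the compounds shown the change occurs twice in all, so the one measured step from compound 1 to compound 2 is the only guide to its size.

For compound 4 the expected step in this assay is a 2.8-fold higher number from compound 3 to compound 4 (0.44 log units; beyond the scatter), resting on the step from compound 1 to compound 2 being a 2.8-fold higher number from compound 1 to compound 2 (0.45 log units; beyond the scatter). Among the compounds with values here, compound 4 is therefore estimated at 30000 nM, with a range from 12000 nM to 75000 nM to allow for the single precedent and the ordinary scatter.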

Compound 4, half-maximal inhibitory concentration: 3340 nM
Estimate against measurement, compound 4: 9.0-fold (0.95 log units) above; measured number below the stated range.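

In this assay, the new step is a 3.2-fold lower number from compound 3 to compound 4 (0.51 log units; beyond the scatter), which runs opposite to the earlier step, so the change does not carry over between these two cores: the same change on two cores in this assay, a 2.8-fold higher number (0.45 log units; beyond the scatter) from compound 1 to compound 2 and a 3.2-fold lower number (0.51 log units; beyond the scatter) from compound 3 to compound 4, 9.2-fold (0.96 log units) apart, beyond the scatter of two such steps

Methoxy in place of hydrogen on an aromatic carbon therefore has no single size or direction in this series, and a step read on one core gives no safe estimate for the other. The two steps do not show what sets them apart: in compound 4 the change reads anilino to (4-methoxyphenyl)amino, compound 2 carries its methoxy on the other aromatic ring outside the shared core, and compound 1 and compound 3 themselves differ in more than one place, so the site of the methoxy and the remaining substituents cannot be separated.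

The compounds shown leave open whether the lower number of compound 4 depends on the bromo group it shares with compound 3 or would also appear with the chloro group of compound 1. They also leave open whether an ethoxy group, a hydroxyl group or an amine at the same place would follow compound 4 or compound 2.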